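A few compounds are considered here, and "the series" means these few. Any claim that something is new, unique, unknown or untested is made for them only; others in the source may bear on it.

Three compounds sharing one core were examined in an ADME assay on HEL cells (Homo sapiens) for cytotoxicity; on this read-out higher numbers stand for lower toxicity in this test and lower numbers for higher toxicity in this test. Compound 1 `O=C(COc1cccc2ccccc12)N/N=C/C=C/c1ccccc1` gives 100 ug/mL, the highest of the two numbers recorded. Compound 2 `C/C(=N\NC(=O)COc1cccc2ccccc12)c1ccccc1Br` gives 20 ug/mL, a gap from compound 1 that lies beyond the usual scatter. For compound 3 `COc1ccc(/C=N/NC(=O)COc2cccc3ccccc23)cc1OC` this assay reports only a limit, >= 20 ug/mL, not a number. Compound 4 `O=C(COc1cccc2ccccc12)N/N=C/c1ccc(F)cc1` has not yet been measured; it differs from compound 1 by 4-fluorophenyl in place of 2-phenylethenyl on a carbon with a double bond to nitrogen. Among the measured compounds shown here, no measured pair separated by a single change is available, so the step is estimated at a 2.0-fold lower number from compound 1 to compound 4 (0.30 log units; within the scatter), a modest move toward a lower number that sits near the edge of the scatter. Compound 4 is therefore expected to give about 50 ug/mL, within 20 ug/mL to 100 ug/mL.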

Compound 4, minimum cytotoxic concentration: 100 ug/mL
For compound 4 the middle estimate is 2.0-fold (0.30 log units) below the measured one; measured number inside the range.
By their numbers in this assay, from the lowest: compound 2; then compounds 1 and 4 (each within the scatter of the next).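

In this assay, among the compounds shown here, 4-fluorophenyl in place of 2-phenylethenyl on a carbon with a double bond to nitrogen gives no change at the digits printed from compound 1 to compound 4 (within the scatter), the first single change that can be read at this position. The double bond outside aromatic rings leaves and a fluorine enters, with no step beyond the scatter on this read-out. No measurement shown here accounts for this result.

Still open, as far as these compounds go, is whether this position accepts a group without an aromatic ring, such as an amine or a carboxylic acid. From the compounds shown here alone, whether a longer chain on this carbon would give a similar number is equally open.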